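Methoxy removal across the series on HOP-62 cells

The source may report more compounds than this note shows. Statements on the series, on what has been measured and on what is new or still open speak of the compounds shown alone.

Compound 1 `COc1ccc2[nH]c(-c3ccccc3)c(C=C(C#N)C#N)c2c1`, compound 2 `COc1ccc(-c2[nH]c3ccc(OC)cc3c2C=C(C#N)C#N)cc1` and compound 3 `COc1ccc2[nH]c(-c3ccccc3)c(/C=C(\C#N)S(=O)(=O)c3ccccc3)c2c1` have been measured in a functional assay on HOP-62 cells (Homo sapiens) for inhibition, read by sulforhodamine B assay, with a stated time of 48 h; on this read-out lower numbers stand for stronger inhibition of growth and higher numbers for weaker inhibition of growth. In this assay compound 1 gives 5300 nM, compound 2 gives 3300 nM and compound 3 gives 8300 nM. For the measured compounds named here, the single counted change from compound 2 to compound 1, (hydrogen in place of methoxy on an aromatic carbon), made a step of a 1.6-fold higher number from compound 2 to compound 1 (0.21 log units; within the scatter). How the core of compound 3 differs from that of compound 2 is not broken down here. Compound 4 `N#C/C(=C\c1c(-c2ccccc2)[nH]c2ccccc12)S(=O)(=O)c1ccccc1` has not yet been measured in this assay. From compound 3 to compound 4 the change is hydrogen in place of methoxy on an aromatic carbon; it is the same kind of change as from compound 2 to compound 1, but the place differs: here the aromatic carbon is part of a fused or bridged system of two rings, meta to a fused ring and para to a fused ring, whereas there it was para to a large group. Because the earlier step was a 1.6-fold higher number from compound 2 to compound 1 (0.21 log units; within the scatter), a step of similar size is expected for compound 4, namely a 1.4-fold higher number from compound 3 to compound 4 (0.16 log units; within the scatter). Compound 4 is therefore estimated at 12000 nM in this assay, with a range from 5000 nM to 30000 nM.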

Compound 4, concentration for 50% growth inhibition: 9300 nM
Beside the measured number, compound 4's estimate is 1.3-fold (0.11 log units) above it; the measured number falls inside the stated range.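

In this assay, hydrogen in place of methoxy on the core of compound 3 gives a 1.1-fold higher number from compound 3 to compound 4 (0.05 log units; within the scatter). Set beside the earlier case, the two steps do not differ: the same change on two cores in this assay, a 1.6-fold higher number (0.21 log units; within the scatter) from compound 2 to compound 1 and a 1.1-fold higher number (0.05 log units; within the scatter) from compound 3 to compound 4, 1.4-fold (0.16 log units) apart, within the scatter of two such steps. For the compounds shown here, on these two cores the change therefore carries over as a step that stays within the scatter, but this does not show that methoxy is without any effect, and with only two pairs, the place of the change and the core vary together, so their contributions cannot be separated.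

The compounds shown leave open whether another group at these places, such as an amine, a carboxylic acid or a longer alkoxy chain, would give a step beyond the scatter. They also leave open whether the same change stays this small on any core outside these two, or on any cell line other than the one used here.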